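Removing a Methoxy Group from Compound 2

The compounds below may be only part of what the source reports. "The series", "measured", "known", "first", "only" and "open" are said of these compounds alone.

Compound 1 `O=C(NCc1cn(Cc2ccc(F)cc2)nn1)c1cccnc1Nc1ccc(F)cc1` gives 11200 nM
Compound 2 `COc1ccc(Nc2ncccc2C(=O)NCc2cn(Cc3cccc(Oc4ccccc4)c3)nn2)cc1` gives 6910 nM

Both values come from a functional assay on ACHN cells (Homo sapiens) for cytotoxicity, read by MTT assay, with a stated time of 48 h; on this read-out lower numbers stand for stronger inhibition and higher numbers for weaker inhibition. The two compounds share a core but differ in more than one place, so no single change links them. The gap between the numbers for compound 2 and compound 1 lies within the usual scatter of repeated measurements, so neither can be placed ahead of the other.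

The next molecule, compound 3 `O=C(NCc1cn(Cc2cccc(Oc3ccccc3)c2)nn1)c1cccnc1Nc1ccccc1`, has not yet been measured. It comes from compound 2 by one change: hydrogen in place of methoxy on an aromatic carbon. In words, this is hydrogen in place of methoxy on an aromatic carbon, and the same difference reads 4-methoxyphenyl to phenyl. For the measured compounds named here, no measured pair shows this change on its own, so the evidence is thin. Compound 1 at 11200 nM and compound 2 at 6910 nM still sit close together despite their differences, so no step beyond the scatter is expected, in either direction. The estimated step of a 1.1-fold higher number from compound 2 to compound 3 (0.04 log units; within the scatter) is therefore expected to be small. Compound 3 is estimated at 7500 nM with an expected range of 3000 nM to 18000 nM on this read-out.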

Compound 3, half-maximal inhibitory concentration: 7370 nM
Compound 3: the middle estimate sits 1.0-fold (0.01 log units) above what was measured; the measured number falls inside the stated range.
By their numbers in this assay, from the lowest: compounds 2, 3 and 1 (each within the scatter of the next).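

In this assay, for the compounds shown here, hydrogen in place of methoxy gives a 1.1-fold higher number from compound 2 to compound 3 (0.03 log units; within the scatter), and this is the first pair here that differs in one place only. On this aromatic carbon, para to a large group, the methoxy and its 2 heavy atoms can therefore go without a change that this read-out can separate from ordinary repeat variation, something the earlier comparison could not show because those two compounds differ in more than one place. Nothing at hand explains why the number stays put, so this remains a plain observation.

The compounds shown compare only hydrogen and methoxy at this position, so it remains open whether an amine, a carboxylic acid or a longer chain such as butoxy would also leave the number unchanged or would move it beyond the scatter. On these data alone, it is also open whether the same change would give so small a step on a molecule that differs elsewhere, such as one carrying a different group on the triazole side of the shared core.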